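Aryl swaps on the shared core: outlook for compound 4

A few compounds are considered here, and "the series" means these few. Any claim that something is new, unique, unknown or untested is made for them only; others in the source may bear on it.

Three members of the series have been measured in an assay on CHO cells for displacement of a labelled ligand from adenosine receptor A1 (Homo sapiens), read by scintillation counting, tested at 10 uM; on this read-out higher numbers stand for more inhibition at the one concentration tested (going by the name of the read-out) and lower numbers for less inhibition. Compound 1 `CC(C)(C)Cc1c(-c2cccnc2)sc(N)c1C(=O)c1ccc(Cl)cc1` gives 1%. Compound 2 `CC(C)(C)Cc1c(-c2ccccn2)sc(N)c1C(=O)c1ccc(Cl)cc1` gives 1%. Compound 3 `CC(C)(C)Cc1c(-c2ccc(F)cc2F)sc(N)c1C(=O)c1ccc(Cl)cc1` gives 1%, which leaves compound 3 level with compounds 1 and 2 at the digits reported; its nearest neighbour by value is compound 1 and its furthest is compound 2, both within the scatter. The measured steps bear this out: no change at the digits printed from compound 1 to compound 2 (within the scatter), no change at the digits printed from compound 1 to compound 3 (within the scatter) and no change at the digits printed from compound 2 to compound 3 (within the scatter).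

Compound 4 `CC(C)(C)Cc1c(-c2ccc(Cl)cc2)sc(N)c1C(=O)c1ccc(Cl)cc1` is the next compound to be measured in this assay. It differs from compound 3 in one place: 4-chlorophenyl in place of 2,4-difluorophenyl on an aromatic carbon. Among the measured compounds shown here, the steps that bear on this change are those from compound 1 to compound 3 and from compound 2 to compound 3, each of which replaced a pyridinyl group with 2,4-difluorophenyl at the same carbon and moved the read-out by nothing beyond the scatter. For the measured compounds named here, no measured step exchanges one halogenated phenyl for another, so the present change is covered only indirectly. Given that every swap at this carbon so far has been flat, the step from compound 3 to compound 4 is expected to be a number 1 percentage points higher from compound 3 to compound 4 (within the scatter). Compound 4 is therefore estimated at 2% in this assay, with an expected range of -8% to 12%.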

Compound 4, a percentage reported as inhibition, at one concentration (the size of the read-out at that concentration, not a potency): 1%
Compound 4: middle estimate off by 1 percentage points, on the high side; measured number inside the range.
By their numbers in this assay, from the lowest: compounds 1, 2, 3 and 4 (each within the scatter of the next).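

In this assay, an exchange of one halogenated phenyl for another at the carbon next to the ring sulfur can now be read directly, and the reading is no change at the digits printed from compound 3 to compound 4 (within the scatter) when 4-chlorophenyl, with one chlorine, replaces 2,4-difluorophenyl, with two fluorines. The same position also now has a pyridinyl to 4-chlorophenyl exchange for each nitrogen placement, with no change at the digits printed from compound 2 to compound 4 (within the scatter) for the pyridin-2-yl group and no change at the digits printed from compound 1 to compound 4 (within the scatter) for the pyridin-3-yl group, so all four aryl groups shown at this carbon stand level in this assay at the digits printed. The compounds shown offer no measured basis for explaining this sameness.

As far as these compounds go, whether any group at this carbon can move the read-out remains open, as every group so far is a six-membered aromatic ring, leaving a morpholine, a carboxylic acid or a longer alkyl chain as untested kinds of substituent in these notes. From the compounds shown here alone, the neopentyl, amino and (4-chlorophenyl)carbonyl groups are the same throughout, so the effect of replacing the amino group with an acetamide, or the neopentyl group with a methyl group, also remains open.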